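The source may report more compounds than this note shows. Statements on the series, on what has been measured and on what is new or still open speak of the compounds shown alone.

Compound 1 `COc1cc(NC(C)CCCNC(=O)Nc2ccc(Br)cc2)c2ncccc2c1` was tested in a functional assay on L1210 cells (Mus musculus) for inhibition, read by MTT assay, with a stated time of 72 h (a lower number here means a stronger inhibitor, a higher number a weaker inhibitor), where compound 1 gives 18000 nM. Compound 3 `COc1cc(NC(C)CCCNC(=O)Nc2ccc(F)cc2)c2ncccc2c1`, which carries fluoro in place of bromo on an aromatic carbon, gives 18000 nM; there is no change at the digits printed from compound 1 to compound 3 (within the scatter), and together these two give the lowest numbers of the three. Compound 2 `COc1cc(NC(C)CCCNC(=O)NNC(=O)Nc2ccc(Cl)cc2)c2ncccc2c1`, which carries ((4-chlorophenyl)carbamoyl)amino in place of 4-bromophenyl on an amide-type nitrogen, gives 58000 nM, so that there is a 3.2-fold higher number from compound 1 to compound 2 (0.51 log units; beyond the scatter). Compound 4 `COc1cc(NC(C)CCCNC(=O)NNC(=O)Nc2ccc(Br)cc2)c2ncccc2c1` has not yet been measured. The change from compound 1 to compound 4 is ((4-bromophenyl)carbamoyl)amino in place of 4-bromophenyl on an amide-type nitrogen. This mirrors the change seen between compound 1 and compound 2, except that the bromine is kept here rather than exchanged for chlorine; since the halogen swap between compound 1 and compound 3 made no difference, the entering ((4-bromophenyl)carbamoyl)amino group is taken as the part that matters. A modest rise in the number is therefore expected, about a 3.1-fold higher number from compound 1 to compound 4 (0.49 log units; beyond the scatter). Compound 4 is estimated at 55000 nM, within a range from 25000 nM to 120000 nM.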

Compound 4, half-maximal inhibitory concentration: 51000 nM
Compound 4: the middle estimate sits 1.1-fold (0.03 log units) above what was measured; measured number inside the range.
By their numbers in this assay, from the lowest: compounds 1 and 3 (each within the scatter of the next); then compounds 4 and 2 (each within the scatter of the next).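

Bromine stays in place in both compound 1 and compound 4. The step between them isolates the longer group: ((4-bromophenyl)carbamoyl)amino in place of 4-bromophenyl on the amide-type nitrogen gives a 2.8-fold higher number from compound 1 to compound 4 (0.45 log units; beyond the scatter) in this assay, so this change weakens inhibition without any change of halogen. The halogen also makes no visible difference with the longer group in place, with bromo in place of chloro giving a 1.1-fold lower number from compound 2 to compound 4 (0.06 log units; within the scatter), and the step that changes both the group and the halogen gives the same size of change, a 2.8-fold higher number from compound 3 to compound 4 (0.45 log units; beyond the scatter). No measurement here explains why the longer group gives weaker inhibition.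

On these data alone, it remains open how a methoxy group or a nitrile in place of the halogen would behave on either linker. The effect of an amine or a carboxylic acid at this end of the molecule is also unknown.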